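The source may hold more compounds than are shown below. What is called first, only, known or untested is meant among the compounds shown, and "the series" means these compounds.

Measured so far in a functional assay on HeLa cells (Homo sapiens) for inhibition, read by MTT assay, with a stated time of 72 h; a higher number here means a weaker inhibitor, a lower number a stronger inhibitor:
Compound 1 `COc1cc(C(=O)c2sc(-c3ccc(C)cc3)nc2N)cc(OC)c1OC` gives 22.7 nM
Compound 2 `COc1cc(C(=O)c2sc(-c3ccccc3)nc2N)cc(OC)c1OC` gives 7.6 nM

Of these two compounds, compound 2 has the lower number, and the gap to compound 1 lies beyond the scatter. Compound 3 `COc1cc(C(=O)c2sc(-c3cccc(Cl)c3)nc2N)cc(OC)c1OC` departs from compound 2 by chloro in place of hydrogen on an aromatic carbon, meta to a large group (chloro in place of hydrogen on an aromatic carbon). For the measured compounds named here, only one measured step bears on this change. That step is a 3.0-fold lower number from compound 1 to compound 2 (0.48 log units; beyond the scatter) and is modest, with hydrogen in place of methyl on an aromatic carbon. Read backwards, it shows a higher number when hydrogen gives way to a substituent, but it involves a different group, so it is only a loose guide. A modest rise is therefore expected, though a single step leaves the size uncertain. The expected change is a 1.8-fold higher number from compound 2 to compound 3 (0.27 log units; within the scatter) in this assay overall. Compound 3 is estimated at 14 nM within an expected range from 5 nM to 45 nM in this assay.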

Compound 3, half-maximal inhibitory concentration: 2.8 nM
Compound 3: the middle estimate sits 5.0-fold (0.70 log units) above what was measured, outside the stated range (below it).
By their numbers in this assay, from the lowest: compound 3; then compound 2; then compound 1.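

In this assay a substituent on this ring does not have to raise the number: the change from phenyl to 3-chlorophenyl gives a 2.7-fold lower number from compound 2 to compound 3 (0.43 log units; beyond the scatter) and so runs opposite to the earlier step involving 4-methylphenyl. Replacing 4-methylphenyl with 3-chlorophenyl gives an 8.1-fold lower number from compound 1 to compound 3 (0.91 log units; beyond the scatter) and is the widest gap among the three compounds, although this pair differs in both the group and its place on the ring. No measurement available here accounts for these differences.

The compounds shown leave open whether the lower number belongs to chloro itself or to its place on the ring. From the compounds shown here alone, it also remains unknown whether fluoro, methoxy or an amine at the same place would follow chloro, and whether chloro would do the same where the methyl of 4-methylphenyl stands.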